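From 3-fluorobenzyl to 4-fluorobenzyl

A few compounds are considered here, and "the series" means these few. Any claim that something is new, unique, unknown or untested is made for them only; others in the source may bear on it.

In a functional assay (Platelet, plasma) for inhibition, with Homo sapiens as the target (on this read-out higher numbers stand for weaker inhibition and lower numbers for stronger inhibition), compound 2 `N#Cc1cc2c(nc1N1CCC(C(=O)NS(=O)(=O)Cc3cccc(F)c3)CC1)COC2=O` gives 70500 nM and stands as the higher of the two plain numbers. Compound 3 `CC1(C(=O)NS(=O)(=O)Cc2ccccc2)CCN(c2nc3c(cc2C#N)C(=O)OC3)CC1` gives 6680 nM as the lower number, with a gap beyond the scatter. Compound 1 `CN1Cc2nc(N3CCC(C(=O)NS(=O)(=O)Cc4ccccc4)CC3)c(C#N)cc2C1=O` shows > 300000 nM as a limit only. Compound 4 `N#Cc1cc2c(nc1N1CCC(C(=O)NS(=O)(=O)Cc3ccc(F)cc3)CC1)COC2=O` has not yet been measured. Its change from compound 2 is 4-fluorophenyl in place of 3-fluorophenyl on a saturated chain carbon bound to a sulfonyl sulfur with 4-fluorophenyl in place of 3-fluorophenyl on a saturated chain carbon bound to a sulfonyl sulfur. The two have the same atoms, joined differently. For the measured compounds named here, no measured pair tests such a move, so no step beyond the scatter is expected in this assay for this swap. The expected step of a 1.2-fold lower number from compound 2 to compound 4 (0.07 log units; within the scatter) is small and has no firm direction. Compound 4 is estimated at 60000 nM within 20000 nM to 180000 nM as its expected range.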

Compound 4, half-maximal inhibitory concentration: 3500 nM
Estimate against measurement, compound 4: 17-fold (1.23 log units) above; measured number outside the range, below it.
By their numbers in this assay, from the lowest: compounds 4 and 3 (each within the scatter of the next); then compound 2. At a limit, above all of these: compound 1.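

In this assay, moving a single fluorine on the phenyl ring, with the atoms otherwise unchanged, gives a 20-fold lower number from compound 2 to compound 4 (1.30 log units; beyond the scatter) and is a large step. For the compounds shown here, this shows that, on a saturated chain carbon bound to a sulfonyl sulfur, the place of the fluorine matters, which no earlier pair could show. Nothing measured here gives a reason for this step.

From the compounds shown here alone, whether 4-chlorophenyl, 4-methoxyphenyl or 2-fluorophenyl would match 4-fluorophenyl stays open. So does whether the same swap has a similar effect on the other cores shown.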